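Removing One Chloro From a Dichlorinated Core

This account rests on a few compounds, and the source may have more. Where it says the series, first, only, none or still open, it means among the compounds named here.

Of the compounds shown here, three have been measured in a functional assay on SN12C cells (Homo sapiens) for cytotoxicity, read by sulforhodamine B assay, with a stated time of 48 h; on this read-out lower numbers stand for stronger inhibition of growth and higher numbers for weaker inhibition of growth: compound 1 `ClCc1ccc(Cn2cnc3c(Cl)ncnc32)cc1`, compound 2 `ClCc1ccc(Cn2cnc3nc(Cl)nc(Cl)c32)cc1` and compound 3 `ClCc1ccc(Cn2cnc3c(Cl)nc(Cl)nc32)cc1`. In this assay compound 1 gives 2340 nM, compound 2 gives 3460 nM and compound 3 gives 20900 nM. Compound 2 and compound 3 are built from the same atoms joined differently; the difference between their two cores is not broken down here. The change from compound 3 to compound 1, (hydrogen in place of chloro on an aromatic carbon), gave an 8.9-fold lower number from compound 3 to compound 1 (0.95 log units; beyond the scatter).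

Compound 4 `ClCc1ccc(Cn2cnc3ncnc(Cl)c32)cc1` has not yet been measured. It is related to compound 2 by hydrogen in place of chloro on an aromatic carbon, which is the same change as that from compound 3 to compound 1. Among the compounds with values here, compound 4 is expected to show a 5.8-fold lower number from compound 2 to compound 4 (0.76 log units; beyond the scatter) in this assay, a step in the same direction but held a little smaller because an 8.9-fold lower number from compound 3 to compound 1 (0.95 log units; beyond the scatter) is the only example of this change and was seen on a differently joined core. The estimate for compound 4 in this assay is therefore 600 nM, with a range from 150 nM to 2500 nM.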

Compound 4, concentration for total growth inhibition: 14800 nM
For compound 4 the middle estimate is 25-fold (1.39 log units) below the measured one; measured number outside the range, above it.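

In this assay, hydrogen in place of chloro on an aromatic carbon gave a 4.3-fold higher number from compound 2 to compound 4 (0.63 log units; beyond the scatter), so the step seen on the core of compound 3 did not carry over to the core of compound 2 and ran the opposite way: the same change on two cores in this assay, an 8.9-fold lower number (0.95 log units; beyond the scatter) from compound 3 to compound 1 and a 4.3-fold higher number (0.63 log units; beyond the scatter) from compound 2 to compound 4, 38-fold (1.58 log units) apart, beyond the scatter of two such steps In this series, then, the outcome of removing this chloro depends on the core that carries it, and a step measured on one core gave no safe guide to the other. Within the data shown here, with only two pairs, this shows that the two cores differ for this change, but it does not show why they differ, nor does it set a rule for any further core.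

The compounds shown leave open how an amine or a methoxy group in place of the chloro would behave on either core. They also leave open whether the split between the cores would persist if an alcohol or a longer chain replaced the chloromethyl group that all four compounds carry.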